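Swapping a methyl for a hydroxy on a triazene side chain

The source may report more compounds than this note shows. Statements on the series, on what has been measured and on what is new or still open speak of the compounds shown alone.

Measured so far:
compound 1 `C=CCN(C)/N=N/c1n[nH]cc1C(N)=O` gives 3.77
compound 2 `CCCN(C)/N=N/c1n[nH]cc1C(N)=O` gives 3.7

Both compounds share the same core and differ only at the end of the chain attached to the amine nitrogen. In a functional assay on L1210 cells (Mus musculus) for antiproliferative activity (a lower number here means a less potent compound, a higher number a more potent compound, by a factor of ten per unit of this negative logarithm), compound 1 gives 3.77, and compound 2 gives 3.7. The step of a number 0.07 log units lower from compound 1 to compound 2 (within the scatter) shows that exchanging one small chain end for another moved the number hardly at all. Compound 2 thus holds the lower of the two numbers, but the two sit within the scatter of each other, so no order between them can be claimed.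

Compound 3 `CN(CCO)/N=N/c1n[nH]cc1C(N)=O` has not yet been measured in this assay. It differs from compound 2 by hydroxy in place of methyl on a saturated chain carbon, two bonds along the chain from an amine nitrogen. Within the data shown here, no measured step involves a hydroxy, so nothing here speaks directly to this change; the only step known, a number 0.07 log units lower from compound 1 to compound 2 (within the scatter), merely shows that the far end of this chain tolerated one exchange without a shift beyond the scatter.

Compound 3 is therefore expected to stay near compound 2, with an estimated step of a number 0.10 log units lower from compound 2 to compound 3 (within the scatter). The estimate for compound 3 in this assay is 3.6, with a range from 3.1 to 4.1.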

Compound 3, logarithm of the reciprocal of the active concentration, log(1/C): 3.1
Beside the measured number, compound 3's estimate is 0.50 log units above it; the measured number falls inside the stated range.
By their numbers in this assay, from the lowest: compound 3; then compounds 2 and 1 (each within the scatter of the next).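

In this assay, this chain end no longer looks indifferent to what is placed on it. The exchange of vinyl for ethyl stayed within the scatter (a number 0.07 log units lower from compound 1 to compound 2 (within the scatter)), but hydroxy in place of methyl, on a saturated chain carbon two bonds along the chain from an amine nitrogen, goes beyond it (a number 0.60 log units lower from compound 2 to compound 3 (beyond the scatter)). The comparison with the unsaturated compound points the same way, with hydroxymethyl in place of vinyl on a saturated chain carbon bound to an amine nitrogen (a number 0.67 log units lower from compound 1 to compound 3 (beyond the scatter)), so both of the hydrocarbon chain ends shown stand above the hydroxy-bearing chain by a modest but real margin.

These three compounds cannot show whether the drop belongs to the hydroxy group in particular or would also appear with a methoxy, an amine or a carboxylic acid at the same place, nor how a longer chain ending in hydroxy would behave. Nothing available here gives a measured reason for the lower number of compound 3.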